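Bromo in Place of Methyl on a Hydroxamic Acid Core

A few compounds are considered here, and "the series" means these few. Any claim that something is new, unique, unknown or untested is made for them only; others in the source may bear on it.

The account follows a pair of hydroxamic acids built on a shared core and tested in a functional assay on ACHN cells (Homo sapiens) for inhibition, read by sulforhodamine B assay; a lower number here means a stronger inhibitor of growth, a higher number a weaker inhibitor of growth. Compound 1, `Cc1cccc(CN2CC=C(CCC(=O)NO)C2=O)c1`, gives 3330 nM in this assay. Compound 2, `Cc1ccc(CCCCN2CC=C(CCC(=O)NO)C2=O)cc1`, carries a longer chain to a differently placed methyl on the aromatic ring and gives 3730 nM in this assay. Compound 1 carries the smaller of the two numbers shown, but its gap to compound 2 is within the scatter of repeated measurements, so the two cannot be told apart on these data.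

The step of interest leads from compound 1 to compound 3, `O=C(CCC1=CCN(Cc2cccc(Br)c2)C1=O)NO`, in which the change is bromo in place of methyl on an aromatic carbon. Going by the values given here, no measured pair in this set shows what such an exchange does in this assay, so there is no step to lean on. The expected step in this assay is small, with no direction beyond the scatter: a 1.1-fold lower number from compound 1 to compound 3 (0.05 log units; within the scatter). Compound 3 is therefore estimated at 3000 nM in this assay, within a range from 1200 nM to 8000 nM.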

Compound 3, concentration for 50% growth inhibition: 3330 nM
Beside the measured number, compound 3's estimate is 1.1-fold (0.05 log units) below it, and the stated range covers the measured number.
By their numbers in this assay, from the lowest: compounds 1, 3 and 2 (each within the scatter of the next).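

In this assay the exchange of methyl for bromo on an aromatic carbon of the six-membered ring, meta to a large group, gives a step that stays inside the scatter (no change at the digits printed from compound 1 to compound 3 (within the scatter)). Going by these compounds alone, compounds 1 and 2 differ in more than one place and so could say nothing about a single group on this ring, whereas this pair gives the first reading for one position and one change, and at this position one heavy atom can stand in for the other without the number in this assay moving beyond the scatter. No measurement accompanies the result that would account for it.

One exchange cannot show whether this position is insensitive to its substituent in general, and an amine, a carboxylic acid, a methoxy group or a trifluoromethyl group at the same carbon would test that more severely than bromo does. On these data alone, compound 2 changes both the chain and the place of the methyl, so the part played by a longer chain with the ring substitution held fixed also remains open.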